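Working notes: amide substituent step from compound 2 to compound 4

This account rests on a few compounds, and the source may have more. Where it says the series, first, only, none or still open, it means among the compounds named here.

Measured compounds:
compound 1 `CCN(Cc1ccccc1)C(=O)c1nn(-c2ccc(F)cc2)c(OC[C@@H](O)C[C@@H](O)CC(=O)O)c1C(C)C` — in an assay on microsomes from liver for inhibition of 3-hydroxy-3-methylglutaryl-coenzyme A reductase (Rattus norvegicus) (on this read-out higher numbers stand for weaker inhibition and lower numbers for stronger inhibition), compound 1 gives 14 nM
compound 2 `CC(C)c1c(C(=O)N2CCCC2c2ccccc2)nn(-c2ccc(F)cc2)c1OC[C@@H](O)C[C@@H](O)CC(=O)O` — compound 2 gives 14 nM
compound 3 `CC(C)c1c(C(=O)N2CCC[C@H](N3CCC4C=CC=CC4C3)C2)nn(-c2ccc(F)cc2)c1CC[C@@H](O)C[C@@H](O)CC(=O)O` — compound 3 gives 10 nM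

All three numbers lie within the scatter of one another. Compound 2 stands level with compound 1 at the digits shown; compound 3, which differs from compound 2 in more than one place, gives a figure within the scatter of both, so nothing separates the three on the read-out.

The step to the unmeasured compound 4 `CC(C)c1c(C(=O)NCc2cccc(Cl)c2)nn(-c2ccc(F)cc2)c1OC[C@@H](O)C[C@@H](O)CC(=O)O` is (3-chlorobenzyl)amino in place of 2-phenylpyrrolidin-1-yl on a carbonyl carbon. Among the measured compounds shown here, the one measured step that bears on it is the swap on the same carbonyl carbon, no change at the digits printed from compound 1 to compound 2 (within the scatter), which left the read-out unchanged. For the measured compounds named here, that step exchanged one amide substituent without a hydrogen-bond donor for another; the entering group here carries one hydrogen-bond donor, and no measured step tests such a change, so the range is kept wide. On the evidence in hand the expected step is a 1.3-fold higher number from compound 2 to compound 4 (0.11 log units; within the scatter), that is, none beyond the scatter in this assay.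

The estimate for compound 4 is 18 nM, with a range from 6 nM to 60 nM.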

Compound 4, half-maximal inhibitory concentration: 5.4 nM
Compound 4: middle estimate off by 3.3-fold (0.52 log units), on the high side; measured number below the stated range.
By their numbers in this assay, from the lowest: compounds 4, 3, 1 and 2 (each within the scatter of the next, the first and the last beyond it).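

In this assay, the substituent on the carbonyl carbon now shows a measurable effect: (3-chlorobenzyl)amino gives a 2.6-fold lower number from compound 2 to compound 4 (0.41 log units; beyond the scatter) in place of 2-phenylpyrrolidin-1-yl and a 2.6-fold lower number from compound 1 to compound 4 (0.41 log units; beyond the scatter) in place of benzyl(ethyl)amino. The earlier swap at this carbon, no change at the digits printed from compound 1 to compound 2 (within the scatter), exchanged two groups without a hydrogen-bond donor and left open whether the position responds to its substituent at all; both new steps are modest, but they show that it does, and the same lower number is reached from either starting amide. Nothing on hand explains these steps.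

The entering group differs from both departing groups in more than one feature, since it brings the amide hydrogen and the chlorine together, so the compounds shown do not assign the step to either. Benzylamino and (3-chlorobenzyl)(methyl)amino on the same carbonyl carbon would separate those two features, and it also remains open whether (3-chlorobenzyl)amino has the same effect on the core of compound 3.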